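The source may hold more compounds than are shown below. What is called first, only, known or untested is meant among the compounds shown, and "the series" means these compounds.

In a functional assay on SW480 cells (Homo sapiens) for cytotoxicity, read by MTT assay, with stated times of 3 h and 24 h (a lower number here means a stronger inhibitor, a higher number a weaker inhibitor), compound 1 `COc1ccc(C2=[N+]3C(=Nc4c(-c5ccccc5)c5c(n4[B-]3(F)F)-c3ccc(OC)cc3CC5)C(c3ccccc3)=C2Br)cc1` gives 1900 nM, while compound 2 `COc1ccc2c(c1)CCc1c(-c3ccccc3)c3n(c1-2)[B-](F)(F)[N+]1=C(c2ccc(C)cc2)C(Br)=C(c2ccccc2)C1=N3` gives 15600 nM, the higher of the two numbers. Compound 3 `COc1ccc2c(c1)CCc1c(-c3ccccc3)c3n(c1-2)[B-](F)(F)[N+]1=C(c2ccc(C)s2)C(Br)=C(c2ccccc2)C1=N3` has not yet been measured and differs from compound 2 in one place: 5-methylthiophen-2-yl in place of 4-methylphenyl on a carbon with a double bond to nitrogen. Among the compounds with values here, the only measured step, an 8.2-fold higher number from compound 1 to compound 2 (0.91 log units; beyond the scatter), came from methyl in place of methoxy on the aromatic group that is replaced here. It offers a guide to size, but none to the direction of a ring swap. In this assay, a smaller change is expected, leaning slightly towards a lower number, with an estimated step of a 1.7-fold lower number from compound 2 to compound 3 (0.24 log units; within the scatter). For compound 3, the expected value is 9000 nM, within an estimated range of 3000 nM to 27000 nM.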

Compound 3, half-maximal inhibitory concentration: > 25000 nM
Compound 3: a limit, no number; the forecaster's own chance of this, stated with the estimate: 10%; middle value at least 2.7-fold (0.44 log units) away from the limit.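

In this assay, compound 3 gives a limit and not a number: the limit of > 25000 nM in this assay, at which 1 of the 3 values shown sits. Exchanging the six-membered ring for the sulfur-containing five-membered ring at this position gives an at least 1.6-fold higher number from compound 2 to compound 3 (0.20 log units; that floor lies within the scatter), so no gain appears, although this floor lies within the scatter. The 4-methoxyphenyl group remains the best of the three groups here, as replacing it with 5-methylthiophen-2-yl gives an at least 13-fold higher number from compound 1 to compound 3 (1.11 log units; beyond the scatter).

From the compounds shown here alone, the true size of the step to compound 3 stays open. It is also unknown how an amine or a carboxylic acid on the aromatic ring at this position would behave.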